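Swapping a cyano group for aminomethyl in compound 3

The source may report more compounds than this note shows. Statements on the series, on what has been measured and on what is new or still open speak of the compounds shown alone.

- Compound 1 `CCn1c(C(=O)NCCCN(C)C)ccc1C(CC)(CC)c1ccc(OCCC(O)(CC)CC)c(C)c1` gives 490 nM
- Compound 2 `CCN(CC)CCNC(=O)c1ccc(C(CC)(CC)c2ccc(OCCC(O)(CC)CC)c(C)c2)n1CC` gives 1630 nM
- Compound 3 `CCn1c(C(=O)NCC#N)ccc1C(CC)(CC)c1ccc(OCCC(O)(CC)CC)c(C)c1` gives > 50000 nM (a limit, not a number)

These values come from a functional assay on Caco-2 cells (Homo sapiens) for antiproliferative activity, read by MTT assay, with a stated time of 48 h (on this read-out lower numbers stand for stronger inhibition and higher numbers for weaker inhibition), and set the scene for one more compound. Compound 3 stands apart from the other two, since its entry > 50000 nM is a limit of the assay and not a number.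

The next compound is compound 4 `CCn1c(C(=O)NCCN)ccc1C(CC)(CC)c1ccc(OCCC(O)(CC)CC)c(C)c1`, in which aminomethyl takes the place of cyano on a saturated chain carbon bound to an amide-type nitrogen (aminomethyl in place of cyano on a saturated chain carbon bound to an amide-type nitrogen). For the measured compounds named here, two measured steps bear most directly on this change. Each ends in cyano at this same place. They are an at least 100-fold higher number from compound 1 to compound 3 (2.00 log units; beyond the scatter) and an at least 30-fold higher number from compound 2 to compound 3 (1.48 log units; beyond the scatter), both large and both starting from a compound with an amino group on its amide chain. Compound 4 regains an amino group, and a 3.3-fold higher number from compound 1 to compound 2 (0.52 log units; beyond the scatter) shows that changing that group between compounds 1 and 2 gave only a modest step. Going by the values given here, no measured compound carries exactly this group, so the expected range stays wide.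

A large step towards lower numbers is therefore expected in this assay. The estimated change is an at least 25-fold lower number from compound 3 to compound 4 (1.39 log units; beyond the scatter). For compound 4 the expected value is 2000 nM, with an estimated range from 500 nM to 10000 nM.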

Compound 4, half-maximal inhibitory concentration: 1740 nM
Beside the measured number, compound 4's estimate is 1.1-fold (0.06 log units) above it; low and high end bracket the measured number.
By their numbers in this assay, from the lowest: compound 1; then compounds 2 and 4 (each within the scatter of the next). At a limit, above all of these: compound 3.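

Aminomethyl in place of cyano gives an at least 28-fold lower number from compound 3 to compound 4 (1.45 log units; beyond the scatter) in this assay, so at this place on the amide chain a plain amino group, with nothing further on its nitrogen, is enough to bring back a measurable value. That plain amino group stands level with the diethylamino group of compound 2 (a 1.1-fold higher number from compound 2 to compound 4 (0.03 log units; within the scatter)), while the (dimethylamino)methyl end of compound 1 keeps a modest edge (a 3.6-fold higher number from compound 1 to compound 4 (0.55 log units; beyond the scatter)). Going by these compounds, the entry of compound 3 is a limit and not a number, so the real size of the first step remains unknown: the limit of > 50000 nM in this assay, at which 1 of the 4 values shown sits.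

Compound 1 differs from compound 4 in both its longer chain and the methyl groups on its nitrogen, so the compounds shown do not separate these two changes; a 3-aminopropyl or a 2-(dimethylamino)ethyl chain on the amide nitrogen would pull them apart. On these data alone, it also remains open whether an amine is needed at all, since no other group that keeps this chain, such as a hydroxyl or a carboxylic acid, appears among them.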